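Esterification of the ring hydroxy in the hemiketal series

The source may report more compounds than this note shows. Statements on the series, on what has been measured and on what is new or still open speak of the compounds shown alone.

Measured so far:
- compound 1 `CCC(=O)[C@@H](C)c1oc([C@H](C)[C@@H]2O[C@](O)([C@@H](C)c3oc(CC)c(C)c(=O)c3C)[C@@H](C)[C@@H](O)[C@@H]2C)c(C)c(=O)c1C`: in a functional assay on A549 cells (Homo sapiens) for inhibition, read by MTT assay, with a stated time of 72 h (a lower number here means a stronger inhibitor, a higher number a weaker inhibitor), compound 1 gives > 100000 nM, which is a limit of the assay.
- compound 2 `CCC(=O)O[C@@H](/C(C)=C/[C@@H](C)c1oc(CC)c(C)c(=O)c1C)[C@H](C)[C@@H](OC(=O)CC(C)C)[C@@H](C)c1oc([C@@H](C)[C@H](CC)OC(C)=O)c(C)c(=O)c1C`: in this assay compound 2 gives 3000 nM.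
- compound 3 `CCC(=O)[C@H](C)c1oc([C@H](C)[C@@H]2O[C@](O)([C@@H](C)c3oc(CC)c(C)c(=O)c3C)[C@@H](C)[C@@H](O)[C@@H]2C)c(C)c(=O)c1C`: in this assay compound 3 gives > 100000 nM, again a limit.

Compound 3 stands at the limit of this assay, as does compound 1; only compound 2 returns a number. Within the data shown here, the single step between compounds differing in one place, a step that the two limits leave unreadable from compound 1 to compound 3, is unreadable because of the limit of > 100000 nM in this assay, at which 2 of the 3 values shown sit; the two differ only because of the fact that compounds 1 and 3 differ only in the configuration as drawn.

Compound 4 `CCC(=O)[C@H](C)c1oc([C@H](C)[C@@H]2O[C@](O)([C@@H](C)c3oc(CC)c(C)c(=O)c3C)[C@@H](C)[C@@H](OC(=O)CC(C)C)[C@@H]2C)c(C)c(=O)c1C` differs from compound 3 by isobutylcarbonyl in place of hydrogen on an oxygen on a saturated carbon. Among the measured compounds shown here, no measured step bears on this change, and the one step known cannot be read. For the measured compounds named here, compound 2 carries the same ester but differs in many places, so its value alone is noted and no step is drawn from it. Compound 4 is therefore estimated at 40000 nM, with a range of 5000 nM to 300000 nM, meaning an expected step of an at least 2.5-fold lower number from compound 3 to compound 4 (0.39 log units; beyond the scatter), with a real chance that only a limit is returned.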

Compound 4, half-maximal inhibitory concentration: 26000 nM
The estimate for compound 4 lay 1.5-fold (0.19 log units) above the measured number; the range from low to high includes it.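

Isobutylcarbonyl in place of hydrogen on an oxygen on a saturated carbon gives an at least 3.8-fold lower number from compound 3 to compound 4 (0.58 log units; beyond the scatter), so this hydroxy can be acylated with a gain in inhibition, and the shared core now returns a number rather than a limit. In this assay compound 3 gives > 100000 nM, which is a limit. The size of the gain therefore has only a lower bound, because of this limit: the limit of > 100000 nM in this assay, at which 2 of the 4 values shown sit.

What the ester contributes, whether as an intact group or otherwise, stays unresolved, as does whether the same ester on the configuration of compound 1 would give a similar number. Also open, on these data alone, is whether a benzoyl group, a longer acyl chain or an amine-bearing ester on this oxygen would lower the number further.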